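Working notes on the amide-tailed series, compounds 1 to 3

This account rests on a few compounds, and the source may have more. Where it says the series, first, only, none or still open, it means among the compounds named here.

Compound 1 `O=C(CI)NCCCCCCC(=O)NCCCCCCNc1ncnc2c1ncn2[C@@H]1O[C@H](COP(=O)(O)OP(=O)(O)OP(=O)(O)O)[C@@H](O)[C@H]1O` and compound 2 `CC(=O)NCCCCCCCCNc1ncnc2c1ncn2[C@@H]1O[C@H](COP(=O)(O)OP(=O)(O)OP(=O)(O)O)[C@@H](O)[C@H]1O` share the same core and differ only in the chain and its terminal group. In an assay on isolated protein for inhibition of hexokinase-1 (Rattus norvegicus), with a stated time of 6 h, tested at 10 mM (a lower number here means less inhibition, a higher number more inhibition at the concentration tested (going by the name of the read-out)), compound 1 gives 0% and compound 2 gives 0%; compound 2 thus stands level with compound 1 at the digits recorded, within the scatter. Within the data shown here, no step between measured compounds is available, so the size of a step cannot be read from the data. Compound 3 `O=C(I)NCC(=O)NCCCCCCNc1ncnc2c1ncn2[C@@H]1O[C@H](COP(=O)(O)OP(=O)(O)OP(=O)(O)O)[C@@H](O)[C@H]1O` carries a group of 8 heavy atoms (3 carbon, 2 nitrogen, 2 oxygen, 1 iodine; no ring) in place of a group of 6 heavy atoms (4 carbon, 1 nitrogen, 1 oxygen; no ring), on a saturated chain carbon, six bonds along the chain from a nitrogen on an aromatic ring. On these two flat readings no change beyond the scatter is expected, and compound 3 is estimated at 2% with a range from 0% to 15%. The expected step of a number 2 percentage points higher from compound 2 to compound 3 (within the scatter) lies within the scatter.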

Compound 3, a percentage reported as inhibition, at one concentration (the size of the read-out at that concentration, not a potency): 0%
For compound 3 the middle estimate is 2 percentage points above the measured one; measured number inside the range.
By their numbers in this assay, from the lowest: compounds 1, 2 and 3 (each within the scatter of the next).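

On the saturated chain carbon six bonds along the chain from a nitrogen on an aromatic ring, putting the iodine-bearing group in place of 2-acetamidoethyl gives no change at the digits printed from compound 2 to compound 3 (within the scatter) in this assay at the concentration tested. On a saturated chain carbon bound to a carbonyl carbon, the smaller iodine-bearing group in place of the larger one gives no change at the digits printed from compound 1 to compound 3 (within the scatter) in the same read-out. Neither exchange separates the compounds.

As far as these compounds go, whether a terminal amine, a carboxylic acid or a longer chain would lift the reading of compound 3 from 0% stays open. No supporting data bear on these level readings.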